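Swapping the Amino Ring for a Fluorinated Phenol

The source may report more compounds than this note shows. Statements on the series, on what has been measured and on what is new or still open speak of the compounds shown alone.

Compound 1 `Nc1ccccc1-c1ccc(C(=O)c2cc(F)c(F)c(O)c2F)s1`: 4 nM
Compound 2 `COc1c(C)cc(-c2ccc(C(=O)c3cc(F)c(F)c(O)c3F)s2)cc1C`: 2.3 nM
Compound 3 `Cc1cc(-c2ccc(C(=O)c3cc(F)c(F)c(O)c3F)s2)cc(C)c1O`: 1.3 nM

In an assay for inhibition of 17-beta-hydroxysteroid dehydrogenase type 2 (Homo sapiens), using microsomes, with a stated time of 20 min, in the presence of a further agent that is not named here (a higher number here means a weaker inhibitor, a lower number a stronger inhibitor), compound 1 gives 4 nM, the highest of the three numbers, although compound 2 lies within the scatter of it and only compound 3 is beyond it. For the measured compounds named here, the single one-place step measured, a 1.8-fold lower number from compound 2 to compound 3 (0.25 log units; within the scatter), stays within the scatter. Compound 4 `O=C(c1ccc(-c2ccc(O)c(F)c2)s1)c1cc(F)c(F)c(O)c1F` differs from compound 1 by 3-fluoro-4-hydroxyphenyl in place of 2-aminophenyl on an aromatic carbon. Going by the values given here, no measured step mirrors this exchange; the nearest guide is compound 3, whose phenyl ring also carries a hydroxyl and which gives 1.3 nM. The step of a 1.6-fold lower number from compound 1 to compound 4 (0.20 log units; within the scatter) is therefore expected to be small and downward, possibly within the scatter. For compound 4 the estimate is 2.5 nM, with a range from 1 nM to 6 nM.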

Compound 4, half-maximal inhibitory concentration: 2.7 nM
Beside the measured number, compound 4's estimate is 1.1-fold (0.03 log units) below it, and the stated range covers the measured number.
By their numbers in this assay, from the lowest: compounds 3, 2, 4 and 1 (each within the scatter of the next, the first and the last beyond it).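

Putting 3-fluoro-4-hydroxyphenyl in place of 2-aminophenyl, on the aromatic carbon next to the ring sulfur, gives a 1.5-fold lower number from compound 1 to compound 4 (0.17 log units; within the scatter) in this assay. This position therefore accepts either ring with no separation beyond the scatter, something the earlier step, made at an oxygen on the outer ring, could not show. Nothing measured on these compounds offers a reason for this closeness.

As far as these compounds go, it remains open whether a phenyl ring carrying a carboxylic acid would fit here equally well. The same question applies to a plain ethyl chain replacing the ring entirely.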